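The source may report more compounds than this note shows. Statements on the series, on what has been measured and on what is new or still open speak of the compounds shown alone.

Of the compounds shown here, two have been tested in a functional assay on CHO cells for antagonist activity at Glucagon receptor (Homo sapiens), read by cAMP accumulation, with stated times of 30 min and 45 min; on this read-out lower numbers stand for stronger inhibition and higher numbers for weaker inhibition. Compound 1 `C[C@H](c1ccc(C(=O)NCCC(=O)O)cc1)N1C(=O)C(c2cccc(Cl)c2)=N[C@]12CC[C@@H](C(C)(C)C)CC2` gives 480 nM, while compound 2 `CC(C)(C)[C@H]1CC[C@]2(CC1)N=C(c1ccc(Cl)cc1)C(=O)N2Cc1ccc(C(=O)NCCC(=O)O)cc1` gives 1400 nM, the higher of the two numbers and therefore the weaker antagonist, the gap to compound 1 lying beyond the usual scatter.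

The next compound, compound 3 `CC(C)(C)[C@H]1CC[C@]2(CC1)N=C(c1cccc(Cl)c1)C(=O)N2Cc1ccc(C(=O)NCCC(=O)O)cc1`, keeps the whole of compound 2 except for one alteration: 3-chlorophenyl in place of 4-chlorophenyl on a carbon with a double bond to nitrogen. The two compounds contain the same atoms, joined differently, so nothing is added or removed; only the chlorine sits at another position of the aromatic ring that hangs from the carbon with a double bond to nitrogen of the shared core.

Within the data shown here, no measured pair shows this exact swap on its own, so the direction can only be guessed. Compound 1 also carries the 3-chlorophenyl on that carbon, and because compound 1 gives 480 nM the move toward that group is expected to lower the number somewhat rather than raise it. The step from compound 2 to compound 3 is therefore expected to be a 2.2-fold lower number from compound 2 to compound 3 (0.33 log units; beyond the scatter), a modest gain. Compound 3 is expected to give about 650 nM, most likely between 250 nM and 1600 nM.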

Compound 3, half-maximal inhibitory concentration: 770 nM
Compound 3: middle estimate off by 1.2-fold (0.07 log units), on the low side; measured number inside the range.
By their numbers in this assay, from the lowest: compounds 1, 3 and 2 (each within the scatter of the next, the first and the last beyond it).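

In this assay the chlorine can sit on either ring position shown, since 3-chlorophenyl in place of 4-chlorophenyl on the carbon with a double bond to nitrogen gives a 1.8-fold lower number from compound 2 to compound 3 (0.26 log units; within the scatter) and that step stays within the usual scatter, so this swap on its own shows no clear effect. Among these compounds, the new compound also isolates the methyl on the saturated chain carbon for the first time: hydrogen in place of that methyl gives a 1.6-fold higher number from compound 1 to compound 3 (0.21 log units; within the scatter) and this step is likewise within the scatter, so the methyl cannot be said to matter on this evidence. No measurement at hand explains either step.

What the compounds shown leave open is how far this tolerance extends, for example whether a plain phenyl without chlorine, or bromine in place of the chlorine, would stay within the scatter at the same carbon. On these data alone, it is also open whether a larger group such as ethyl in place of the methyl would produce a step that can be told apart from the scatter.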